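This account rests on a few compounds, and the source may have more. Where it says the series, first, only, none or still open, it means among the compounds named here.

Compound 2 `CN(C)[C@H]1CC[C@H](Nc2ncnn3ccc([C@H]4CC[C@H](C(N)=O)CC4)c23)CC1`, measured in a physicochemical assay for lipophilicity, using the shake flask method, at pH 7.4 (a higher number here means a more lipophilic compound, a lower number a more polar compound), gives 0.2, the second highest of three numbers. Among the measured compounds shown here, compound 1 `CC(=O)N1CCN([C@H]2CC[C@H](Nc3ncnn4ccc([C@H]5CC[C@H](C(N)=O)CC5)c34)CC2)CC1` gives 1.4, and the single change of a number 1.20 log units lower from compound 1 to compound 2 (beyond the scatter) separates the two. Compound 3 `Cn1ccc2ncnc(N[C@H]3CC[C@H](N(C)C)CC3)c21`, which carries a different core and lacks the 4-carbamoylcyclohexyl group, gives -0.8. Compound 4 `CN(C)[C@H]1CC[C@H](Nc2ncnn3cccc23)CC1` differs from compound 2 by hydrogen in place of 4-carbamoylcyclohexyl on an aromatic carbon. For the measured compounds named here, no measured step matches this change; the one step available, from compound 1 to compound 2, concerns a different part of the molecule. The group that leaves contains both a carbon ring and an amide, so the step is expected to be modest, with compound 4 estimated at -0.2, a change of a number 0.40 log units lower from compound 2 to compound 4 (beyond the scatter), within the range -1 to 0.6.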

Compound 4, distribution coefficient: 0
Beside the measured number, compound 4's estimate is 0.20 log units below it; the range from low to high includes it.
By their numbers in this assay, from the lowest: compound 3; then compounds 4 and 2 (each within the scatter of the next); then compound 1.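

In this assay, hydrogen in place of 4-carbamoylcyclohexyl on this aromatic carbon gives a number 0.20 log units lower from compound 2 to compound 4 (within the scatter), so losing this whole group leaves the reading within the scatter. The earlier change on a saturated ring carbon, a number 1.20 log units lower from compound 1 to compound 2 (beyond the scatter), lies beyond it. Nothing measured here explains this result.

The compounds shown do not separate the carbon ring from the amide within the departing group. A plain cyclohexyl group at this position, or a carboxylic acid in place of the amide, would be needed to tell them apart.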